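This account rests on a few compounds, and the source may have more. Where it says the series, first, only, none or still open, it means among the compounds named here.

Within the data shown here, compound 1, `CN1CCN(CCCS(=O)(=O)c2ccc3nc(NC(=O)NC(=O)c4cccc(-n5cccn5)c4Cl)sc3c2)CC1`, is the more polar of the two compounds measured so far in a physicochemical assay for lipophilicity; a lower number here means a more polar compound, a higher number a more lipophilic compound: in this assay compound 1 gives 1.6. The other measured compound, compound 2, `CCN(CC)CCCS(=O)(=O)c1ccc2nc(NC(=O)NC(=O)c3cc(-n4cccn4)ccc3Cl)sc2c1`, gives 2.1 in this assay, a number that lies beyond the usual scatter above the value of compound 1. Compound 2 differs from compound 1 in more than one place, so the two values only show that compound 2 is the more lipophilic of the pair; no single change accounts for the gap.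

The step under consideration leads from compound 1 to compound 3, `CN1CCN(CCCS(=O)(=O)c2ccc3nc(NC(=O)NC(=O)c4cc(-n5cccn5)ccc4Cl)sc3c2)CC1`. The two compounds are built from the same atoms, joined differently: 2-chloro-5-(1H-pyrazol-1-yl)phenyl in place of 2-chloro-3-(1H-pyrazol-1-yl)phenyl on a carbonyl carbon. Nothing in the measured data isolates this rearrangement. Compound 2 carries the same 2-chloro-5-(1H-pyrazol-1-yl)phenyl group on its carbonyl carbon, but its other differences from compound 1 prevent a clean reading. Compound 3 is therefore expected to stay close to compound 1, with an estimated step from compound 1 to compound 3 of a number 0.10 log units higher from compound 1 to compound 3 (within the scatter), within the scatter. The estimate for compound 3 in this assay is 1.7, ranging from 1.3 to 2.1.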

Compound 3, distribution coefficient: 2
For compound 3 the middle estimate is 0.30 log units below the measured one, within the range that was stated.
By their numbers in this assay, from the lowest: compound 1; then compounds 3 and 2 (each within the scatter of the next).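

In this assay, 2-chloro-5-(1H-pyrazol-1-yl)phenyl in place of 2-chloro-3-(1H-pyrazol-1-yl)phenyl on a carbonyl carbon gives a number 0.40 log units higher from compound 1 to compound 3 (beyond the scatter), so with the rest of the structure held constant, rejoining the same atoms in this group is enough to shift the read-out. With the 2-chloro-5-(1H-pyrazol-1-yl)phenyl group held constant, 4-methylpiperazin-1-yl in place of diethylamino on a saturated chain carbon, three bonds along the chain from a sulfonyl sulfur, gives only a number 0.10 log units lower from compound 2 to compound 3 (within the scatter), so this exchange does not separate the two compounds in this assay. No measurement shown here offers an explanation for the shift between the two pyrazolyl-substituted phenyl groups.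

The compounds shown test the rearrangement only with 4-methylpiperazin-1-yl on the chain, so it remains open whether a step of similar size would appear with diethylamino or morpholin-4-yl there. On these data alone, it also remains open how this assay would respond to a 1H-imidazol-1-yl ring in place of the 1H-pyrazol-1-yl ring on the same phenyl group.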